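From Chlorophenyl to Dimethoxyphenyl on a Shared Core

The compounds below may be only part of what the source reports. "The series", "measured", "known", "first", "only" and "open" are said of these compounds alone.

Compound 1 (`COc1ccc(-c2ccc(-c3ccc(-c4nc5c(O)cccc5[nH]4)cc3)cc2)cc1`) gives 3210 nM in a functional assay on HOP-62 cells (Homo sapiens) for inhibition, read by sulforhodamine B assay (a higher number here means a weaker inhibitor of growth, a lower number a stronger inhibitor of growth), and compound 2 (`Oc1cccc2[nH]c(-c3ccc(-c4ccc(-c5cccc(Cl)c5)cc4)cc3)nc12`) gives 2260 nM on the same test. These two values lie within the scatter of each other, so compound 2 cannot be ranked against compound 1 on these numbers.

Compound 3 (`COc1ccc(-c2ccc(-c3ccc(-c4nc5c(O)cccc5[nH]4)cc3)cc2)cc1OC`) has not yet been measured. It carries 3,4-dimethoxyphenyl in place of the 3-chlorophenyl of compound 2, on an aromatic carbon para to a large group (3,4-dimethoxyphenyl in place of 3-chlorophenyl on an aromatic carbon).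

Within the data shown here, one measured step bears on this change, made at the same place: putting 3-chlorophenyl in place of 4-methoxyphenyl gave a 1.4-fold lower number from compound 1 to compound 2 (0.15 log units; within the scatter) in this assay for that swap. Among the measured compounds shown here, the group entering compound 3 is a close relative of the 4-methoxyphenyl of compound 1 (3210 nM), and no measured compound shows what a second methoxy group does. A single step is thin evidence, so no change beyond the scatter is expected, and the estimate reads (a 1.3-fold higher number from compound 2 to compound 3 (0.11 log units; within the scatter)). The estimated value for compound 3 is 2900 nM (expected range 1200 nM to 7000 nM).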

Compound 3, concentration for 50% growth inhibition: 2210 nM
For compound 3 the middle estimate is 1.3-fold (0.12 log units) above the measured one; measured number inside the range.
By their numbers in this assay, from the lowest: compounds 3, 2 and 1 (each within the scatter of the next).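

Replacing 3-chlorophenyl with 3,4-dimethoxyphenyl at this position gives a 1.0-fold lower number from compound 2 to compound 3 (0.01 log units; within the scatter) in this assay, and adding a methoxy in place of hydrogen on the ring of compound 1 gives a 1.5-fold lower number from compound 1 to compound 3 (0.16 log units; within the scatter). This position on an aromatic carbon, para to a large group, therefore now holds three different substituted phenyl groups with no step beyond the scatter, even though 3,4-dimethoxyphenyl has more heavy atoms and more hydrogen-bond acceptors than the 3-chlorophenyl it replaces. Nothing available explains why these numbers stay so close together.

From the compounds shown here alone, all three groups at this position are phenyl rings with no net charge, so it remains open whether a ring bearing an amine or a carboxylic acid, or a longer alkyl chain in place of the ring, would move the number beyond the scatter. The shared core is also the same in all three compounds, which leaves open how much a change elsewhere in the molecule would matter.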